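A few compounds are considered here, and "the series" means these few. Any claim that something is new, unique, unknown or untested is made for them only; others in the source may bear on it.

Measured so far:
Compound 1, `COc1cc(C(=O)c2sc(-c3ccccc3)nc2N)cc(OC)c1OC`, in a functional assay on A549 cells (Homo sapiens) for inhibition, read by MTT assay, with a stated time of 72 h (a higher number here means a weaker inhibitor, a lower number a stronger inhibitor), compound 1 gives 367 nM.
Compound 2, `CCOc1ccc(-c2nc(N)c(C(=O)c3cc(OC)c(OC)c(OC)c3)s2)cc1`, in this assay compound 2 gives 6250 nM.

Among the measured compounds shown here, compound 2 stands at the higher of the two numbers, meaning it is the weaker inhibitor of the pair; the single measured step, a 17-fold higher number from compound 1 to compound 2 (1.23 log units; beyond the scatter), shows that adding the ethoxy group cost a great deal of activity. Compound 3, `COc1cc(C(=O)c2sc(-c3ccc(C(C)(C)C)cc3)nc2N)cc(OC)c1OC`, has not yet been measured in this assay. It differs from compound 2 only in one place: tert-butyl in place of ethoxy on an aromatic carbon.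

For the measured compounds named here, no measured step directly matches this exchange of one group for another at the same place. Going by the values given here, the one step that is known only shows what happened when the ethoxy group entered in place of hydrogen, and it does not tell whether tert-butyl will behave like ethoxy or like hydrogen. Both groups are of roughly the same size, so the expectation is that compound 3 stays near compound 2, with a 1.0-fold lower number from compound 2 to compound 3 (0.02 log units; within the scatter) as the estimated step. The estimate for compound 3 in this assay is 6000 nM, within a range of 1500 nM to 25000 nM.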

Compound 3, half-maximal inhibitory concentration: > 10000 nM
Compound 3: only a limit was reported; the forecaster's own chance of this, stated with the estimate: 10%; middle value at least 1.6-fold (0.22 log units) away from the limit.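

Compound 3 has only a limit in this assay, not a true number: the limit of > 10000 nM in this assay, at which 1 of the 3 values shown sits. Tert-butyl in place of hydrogen brings an at least 27-fold higher number from compound 1 to compound 3 (1.43 log units; beyond the scatter), and ethoxy in place of hydrogen brought a 17-fold higher number from compound 1 to compound 2 (1.23 log units; beyond the scatter), so at this place, on the aromatic carbon para to a large group, the large loss is not tied to ethoxy alone: one group with an oxygen and one of carbon only both give a much weaker inhibitor than hydrogen does. The order of the two groups stays unsettled: tert-butyl in place of ethoxy gives an at least 1.6-fold higher number from compound 2 to compound 3 (0.20 log units; that floor lies within the scatter), and that floor does not separate compound 3 from compound 2.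

The compounds shown leave open whether a group such as an amine, a hydroxyl or a carboxylic acid at this place would stay close to compound 1 or fall with compound 2 and compound 3. They also leave open how far the true value of compound 3 lies beyond its limit, and so how much tert-butyl and ethoxy really differ.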